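A few compounds are considered here, and "the series" means these few. Any claim that something is new, unique, unknown or untested is made for them only; others in the source may bear on it.

Compound 1 `CC(C)[C@H]1C(O)=C(C2=NS(=O)(=O)c3c(OCC(N)=O)cccc32)C(=O)N1Cc1ccccc1` and compound 2 `CC(C)[C@H]1C(O)=C(C2=NS(=O)(=O)c3c(OCC#N)cccc32)C(=O)N1Cc1ccccc1` share one core and differ by cyano in place of carbamoyl on a saturated chain carbon bound to an oxygen on an aromatic ring. In an ADME assay on Huh-7 cells (Homo sapiens) for cytotoxicity, with a stated time of 72 h (a higher number here means that more compound is tolerated, a lower number that less compound is tolerated), compound 1 gives > 33000 nM, which is a limit of the assay rather than a number. In this assay compound 2 gives > 33000 nM, again a limit and not a number. The step that the two limits leave unreadable from compound 1 to compound 2 is therefore not readable in size. Compound 3 `CC(C)(C)[C@H]1C(O)=C(C2=NS(=O)(=O)c3c(OCC(N)=O)cccc32)C(=O)N1Cc1ccc(F)c(Cl)c1` is built on another core; the difference between the two cores is not broken down here. In this assay compound 3 gives > 33000 nM, once more a limit. Compound 4 `CC(C)(C)[C@H]1C(O)=C(C2=NS(=O)(=O)c3c(OCC#N)cccc32)C(=O)N1Cc1ccc(F)c(Cl)c1` differs from compound 3 by cyano in place of carbamoyl on a saturated chain carbon bound to an oxygen on an aromatic ring, the same change as from compound 1 to compound 2. Because the limit of > 33000 nM in this assay, at which 3 of the 3 values shown sit, is where every measured value sits, the expected step is a number no higher from compound 3 to compound 4 (the limit leaves the size open). Compound 4 is thus expected to give 33000 nM in this assay.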

Compound 4, half-maximal cytotoxic concentration: > 33000 nM
Compound 4 gave a limit, no number; the forecaster's own chance of this, stated with the estimate: 85%; the middle value sits exactly at the limit.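

Going by these compounds alone, compound 3 and compound 4 each give only a limit of the assay and not a number, so no step between them can be read in this assay. Going by these compounds, whether cyano in place of carbamoyl changes the tolerated concentration at all stays open.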